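The source may report more compounds than this note shows. Statements on the series, on what has been measured and on what is new or still open speak of the compounds shown alone.

Measured so far:
- compound 1 `Cc1ccc(S(=O)(=O)N(C)CC(C)C)cc1C#Cc1cc(Cl)ccc1OCC(=O)O`: 119 mL.min-1.g-1
- compound 2 `Cc1ccc(S(=O)(=O)NC(C)C)cc1C#Cc1cc(Cl)ccc1OCC(=O)O`: 12 mL.min-1.g-1
- compound 3 `Cc1ccc(S(=O)(=O)N(C)C)cc1C#Cc1cc(Cl)ccc1OCC(=O)O`: 22 mL.min-1.g-1

All three were run in an in vitro ADME assay on microsomes from liver (Rattus norvegicus) for metabolic stability, read by LC-MS, tested at 1 uM; a higher number here means faster removal of the compound, a lower number slower removal. Compound 3 sits second highest of the three numbers; its nearest neighbour is compound 2, a 1.8-fold higher number from compound 2 to compound 3 (0.26 log units; within the scatter), a gap inside the scatter, while the gap to compound 1 is real, a 5.4-fold lower number from compound 1 to compound 3 (0.73 log units; beyond the scatter).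

Compound 4 `Cc1ccc(S(=O)(=O)N2CCCCC2C)cc1C#Cc1cc(Cl)ccc1OCC(=O)O` is the next entry and has not yet been run in this assay. It differs from compound 3 in one place: 2-methylpiperidin-1-yl in place of dimethylamino on a sulfonyl sulfur.

Among the measured compounds shown here, two measured steps bear on it, both altering the group on the sulfonyl sulfur. From compound 1 to compound 3 the removal of isopropyl from the saturated chain carbon bound to the sulfonamide nitrogen gave a 5.4-fold lower number from compound 1 to compound 3 (0.73 log units; beyond the scatter), and from compound 1 to compound 2 the swap to isopropylamino gave a 9.9-fold lower number from compound 1 to compound 2 (1.00 log units; beyond the scatter). Within the series, then, the larger substituent on that sulfur sits with the higher clearance number, and compound 4 moves back toward a larger substituent, of a ring type not yet represented. A rise beyond the scatter is therefore expected for compound 4, though its size is uncertain; the step is estimated as a 2.7-fold higher number from compound 3 to compound 4 (0.44 log units; beyond the scatter). The value for compound 4 is expected to be about 60 mL.min-1.g-1, with a range of 25 mL.min-1.g-1 to 150 mL.min-1.g-1.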

Compound 4, intrinsic clearance in microsomes: 418 mL.min-1.g-1
Beside the measured number, compound 4's estimate is 7.0-fold (0.84 log units) below it, and the stated range ends below it.
By their numbers in this assay, from the lowest: compounds 2 and 3 (each within the scatter of the next); then compound 1; then compound 4.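

In this assay, 2-methylpiperidin-1-yl on the sulfonyl sulfur gives the highest number of the four compounds, with a 19-fold higher number from compound 3 to compound 4 (1.28 log units; beyond the scatter) and a 35-fold higher number from compound 2 to compound 4 (1.54 log units; beyond the scatter) as the two large steps, both wider than any step among the open-chain groups. The ring-bearing group also goes past isobutyl(methyl)amino, with a 3.5-fold higher number from compound 1 to compound 4 (0.55 log units; beyond the scatter) as a modest but real step, so compound 1 no longer marks the top of the range at this position and the sulfonyl sulfur substituent now spans a wider range of removal rates than the first three compounds suggested. Nothing measured here accounts for the size of these steps.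

The compounds shown do not separate the contribution of the ring from that of its methyl, and piperidin-1-yl without the methyl would be the direct comparison with compound 4. On these data alone, whether a ring with a second hetero atom, such as morpholin-4-yl, or a smaller ring, such as pyrrolidin-1-yl, would sit with compound 4 or with compound 3 also remains open.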